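The source may report more compounds than this note shows. Statements on the series, on what has been measured and on what is new or still open speak of the compounds shown alone.

In an ADME assay on MT2 cells (Homo sapiens) for cytotoxicity, read by XTT assay, with a stated time of 4 days (a lower number here means that less compound is tolerated, a higher number that more compound is tolerated), compound 1 `Cc1nc(C(NC(=O)C(=O)Nc2ccc(Cl)cc2)C2CCNCC2)sc1CO` gives > 81000 nM, which is a limit and not a number. Compound 2 `Cc1nc(C(NC(=O)C(=O)Nc2ccc(Cl)cc2)C2CCNCC2)sc1CCO` gives > 78500 nM, also a limit. Compound 3 `Cc1nc(C(NC(=O)C(=O)Nc2ccc(F)c(Cl)c2)C2CCCCN2)sc1CO` gives > 77800 nM, again a limit. Compound 2 therefore has no exact value, and neither do the other two compounds. Compound 4 `Cc1nc(C(NC(=O)C(=O)Nc2ccc(Cl)cc2)C2CCCN2)sc1CCO` differs from compound 2 at one place: pyrrolidin-2-yl in place of piperidin-4-yl on a saturated chain carbon bound to an amide-type nitrogen and an aromatic carbon. Among the measured compounds shown here, the only measured step, a step that the two limits leave unreadable from compound 1 to compound 2, lies elsewhere in the molecule, and its size cannot be read. For the measured compounds named here, no measured step covers this ring exchange, so no step beyond the scatter is expected in this assay. The expected step that the limit leaves unreadable from compound 2 to compound 4 is an estimate resting on limits alone. The estimate for compound 4 is 80000 nM, with an expected range from 35000 nM to 120000 nM.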

Compound 4, half-maximal cytotoxic concentration: 42000 nM
Compound 4: middle estimate off by 1.9-fold (0.28 log units), on the high side, and the stated range covers the measured number.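

In this assay, among the compounds shown here, compound 4 is the first compound here with an exact number, and the earlier step cannot be read. Pyrrolidin-2-yl in place of piperidin-4-yl, on a saturated chain carbon bound to an amide-type nitrogen and an aromatic carbon, gives an at least 1.8-fold lower number from compound 2 to compound 4 (0.27 log units; that floor lies within the scatter). This size is only a floor because compound 2 stands at a limit: the limit of > 78500 nM in this assay, at which 1 of the 4 values shown sits.

On these data alone, whether ring size or the ring's point of attachment carries this step stays open. So does how pyrrolidin-3-yl or an open-chain aminoethyl group would read at this place.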